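The source may hold more compounds than are shown below. What is called first, only, known or untested is meant among the compounds shown, and "the series" means these compounds.

Measured compounds in this set:
Compound 1 `CCCc1nnc(O)n2c(CCC)nc(C)c12`: in a functional assay for inhibition, with Homo sapiens as the target (on this read-out lower numbers stand for stronger inhibition and higher numbers for weaker inhibition), compound 1 gives 16000 nM.
Compound 2 `CCCc1ncc2c(C)nnc(O)n12`: in this assay compound 2 gives only a limit, > 48000 nM.

Where compound 2 stands: its result is a limit of this assay and not a number, (the limit of > 48000 nM in this assay, at which 1 of the 2 values shown sits). Compound 1, by contrast, gives a measured number. Among the measured compounds shown here, no step between the two is counted, since the two cores differ in more than one place, so the pair says no more than what the two values show.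

Compound 3 `CCCc1nc(C)c2c(C)nnc(O)n12` is not yet measured. It differs from compound 2 by methyl in place of hydrogen on an aromatic carbon. For the measured compounds named here, no measured step in this set parallels that change, so the expectation rests on compound 2 alone. The expected step from compound 2 to compound 3 is an at least 1.6-fold lower number from compound 2 to compound 3 (0.20 log units; that floor lies within the scatter), that is, toward stronger inhibition but not clearly beyond the scatter of this assay. For compound 3 the estimate in this assay is 30000 nM, with a range from 8000 nM to 100000 nM, and a real chance that the result is again only a limit.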

Compound 3, half-maximal inhibitory concentration: 14000 nM
Beside the measured number, compound 3's estimate is 2.1-fold (0.33 log units) above it; measured number inside the range.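

Methyl in place of hydrogen on the aromatic carbon of the five-membered aromatic ring gives, in this assay, an at least 3.4-fold lower number from compound 2 to compound 3 (0.53 log units; beyond the scatter); this is the first read-out of a change at this position, and it shows that this single added carbon is enough for a step beyond the scatter. Compound 2 stands only at a limit of the assay, so this step is a floor and its true size stays open: the limit of > 48000 nM in this assay, at which 1 of the 3 values shown sits.

At the other place that changes, hydrogen in place of ethyl on a saturated chain carbon bound to an aromatic carbon gives a 1.1-fold lower number from compound 1 to compound 3 (0.06 log units; within the scatter), so the shortening of that chain leaves no difference that can be read here.

On these data alone, the series shows only hydrogen and methyl on the aromatic carbon of the five-membered ring, so it remains open whether a longer chain such as propyl, a trifluoromethyl group or an amine there would carry the trend further or reverse it. Nor do these compounds show whether the same methyl step holds on a core that carries another group in place of the hydroxyl, for example an amine or a methoxy group.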